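Amide to sulfonamide swap on the chloroaryl arm

The source may report more compounds than this note shows. Statements on the series, on what has been measured and on what is new or still open speak of the compounds shown alone.

Measured so far in a functional assay on HL-60 cells (Homo sapiens) for antiproliferative activity, read by MTT assay, with a stated time of 72 h; on this read-out higher numbers stand for weaker inhibition and lower numbers for stronger inhibition:
compound 1 `CN(C(=O)c1ccc(Cl)cc1)c1ccc2[nH]c(-c3n[nH]c4ccccc34)cc2n1`: 450 nM
compound 2 `CN(C(=O)c1ccccc1)c1ccc2[nH]c(-c3n[nH]c4cc(Cl)ccc34)cc2n1`: 5620 nM

Compound 1 stands lowest of the two numbers; compound 2 gives a higher number, and that gap is beyond the usual scatter. The two compounds differ in more than one place, so no single structural step can be read from the pair, and the two values are noted only as they stand.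

Compound 3 `CN(c1ccc2[nH]c(-c3n[nH]c4ccccc34)cc2n1)S(=O)(=O)c1ccc(Cl)cc1` is the next one to be measured in this assay. It keeps the core of compound 1 and differs from it in one place: (4-chlorophenyl)sulfonyl in place of (4-chlorophenyl)carbonyl on a nitrogen on an aromatic ring. Among the compounds with values here, no measured pair shows a change of this kind, so the size and direction of the step have to be set without a precedent. A modest move toward a higher number is expected, with the expected step of a 2.4-fold higher number from compound 1 to compound 3 (0.39 log units; beyond the scatter) possibly not clearing the scatter. Compound 3 is expected to give 1100 nM in this assay, within 300 nM to 4500 nM.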

Compound 3, half-maximal inhibitory concentration: 770 nM
Beside the measured number, compound 3's estimate is 1.4-fold (0.15 log units) above it; measured number inside the range.
By their numbers in this assay, from the lowest: compounds 1 and 3 (each within the scatter of the next); then compound 2.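

Within the data shown here, the change of (4-chlorophenyl)carbonyl to (4-chlorophenyl)sulfonyl on a nitrogen on an aromatic ring is the first single-place step, and in this assay it reads as a 1.7-fold higher number from compound 1 to compound 3 (0.23 log units; within the scatter). On this read-out, the two groups cannot be told apart at this position, so with the 4-chlorophenyl arm and the core of compound 1 held fixed, the carbonyl is not required to keep the number at the level of compound 1, and the sulfonyl, with its extra heavy atom and extra hydrogen-bond acceptor, is accepted here. Nothing available bears on why the two groups read alike.

This single pair leaves open whether the same match holds on an arm without the chlorine or with the chlorine elsewhere, and compound 2, which differs from compound 1 and compound 3 in more than one place, cannot settle that. Also open, going by these compounds, is how this nitrogen responds to a plain methylene in place of the carbonyl or sulfonyl, or to a carboxylic acid or an amine in place of the chlorine on the arm.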